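Adding a second isopropyl to the amine of compound 3

The source may report more compounds than this note shows. Statements on the series, on what has been measured and on what is new or still open speak of the compounds shown alone.

In a functional assay on MCF7 cells (Homo sapiens) for antiproliferative activity (a higher number here means a weaker inhibitor, a lower number a stronger inhibitor), compound 1 (`CC(C)=CCc1cc(C(=O)Nc2cc3ccc(OCCC4CCCCN4)c(C)c3oc2=O)ccc1O`) gives 710 nM and compound 3 (`CC(C)=CCc1cc(C(=O)Nc2cc3ccc(OCCCNC(C)C)c(C)c3oc2=O)ccc1O`) gives 740 nM, and these two values lie within the scatter of each other, as a 1.0-fold higher number from compound 1 to compound 3 (0.02 log units; within the scatter) shows. Compound 2 (`CC(C)=CCc1cc(C(=O)Nc2cc3ccc(OCCCN4CCCCC4)c(C)c3oc2=O)ccc1O`) reaches only a limit of the assay, > 50000 nM. Compound 3 therefore stands level with compound 1 and far from compound 2.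

Compound 4 (`CC(C)=CCc1cc(C(=O)Nc2cc3ccc(OCCCN(C(C)C)C(C)C)c(C)c3oc2=O)ccc1O`) carries isopropyl in place of hydrogen on an amine nitrogen, so isopropylamino becomes diisopropylamino: isopropyl in place of hydrogen on an amine nitrogen. That change removes the amine hydrogen, which compound 1 and compound 3 both keep and compound 2 lacks. Among the measured compounds shown here, two measured steps bear on this, an at least 70-fold higher number from compound 1 to compound 2 (1.84 log units; beyond the scatter) and an at least 67-fold lower number from compound 2 to compound 3 (1.82 log units; beyond the scatter), and both are large and beyond the scatter. In these three compounds, a number is obtained only where the amine hydrogen is present. However, compound 2 is the sole example without it, and it has a ring at the nitrogen where compound 4 has none. A clear move to a weaker inhibitor in this assay is thus expected, though perhaps not all the way to the limit. The expected change is a 12-fold higher number from compound 3 to compound 4 (1.09 log units; beyond the scatter). For compound 4 the estimated value is 9000 nM, with an expected range of 1500 nM to 50000 nM.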

Compound 4, half-maximal inhibitory concentration: 1310 nM
Compound 4: the middle estimate sits 6.9-fold (0.84 log units) above what was measured; measured number below the stated range.
By their numbers in this assay, from the lowest: compounds 1, 3 and 4 (each within the scatter of the next). At a limit, above all of these: compound 2.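

Compound 4 shows that, at this amine nitrogen, the amine hydrogen is not needed for a measured value in this assay: with isopropyl in place of hydrogen, the result stays within the scatter (a 1.8-fold higher number from compound 3 to compound 4 (0.25 log units; within the scatter)), and the same holds against the piperidin-2-yl side chain (a 1.8-fold higher number from compound 1 to compound 4 (0.27 log units; within the scatter)). The earlier link between a measured value and the presence of the amine hydrogen therefore fails, and compound 2 alone stands apart from compounds 1, 3 and 4, even against compound 4, which also lacks that hydrogen (an at least 38-fold lower number from compound 2 to compound 4 (1.58 log units; beyond the scatter)). Compound 2 sits at a limit of the assay and carries no number: the limit of > 50000 nM in this assay, at which 1 of the 4 values shown sits.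

As far as these compounds go, whether pyrrolidin-1-yl or morpholin-4-yl at this nitrogen would read like piperidin-1-yl or like diisopropylamino remains open, and so does whether the gap belongs to piperidin-1-yl alone or to ring amines on this chain in general. Also open, from the compounds shown here alone, is whether an open-chain dimethylamino or diethylamino group would stay within the scatter of compound 3 and compound 4 in this assay.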